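The source may report more compounds than this note shows. Statements on the series, on what has been measured and on what is new or still open speak of the compounds shown alone.

Three close relatives have been measured in a functional assay on HT-29 cells (Homo sapiens) for antiproliferative activity, read by MTT assay, with a stated time of 48 h; a lower number here means a stronger inhibitor, a higher number a weaker inhibitor. Compound 1 `O=C(Nc1ccccc1)Nc1ccc(OC(=O)c2ccc(F)cc2)cc1` gives 128000 nM, compound 2 `Cc1ccc(C(=O)Oc2ccc(NC(=O)Nc3ccccc3)cc2)cc1` gives 19900 nM, and compound 3 `O=C(Nc1ccc(F)cc1)Nc1ccc(OC(=O)c2ccccc2)cc1` gives 94400 nM. Compound 1 and compound 3 carry the same atoms joined differently; the difference between the two cores is not broken down here, and their two numbers lie within the usual scatter of each other. Compound 2 differs from compound 1 in one place (methyl in place of fluoro on an aromatic carbon). That change gave a 6.4-fold lower number from compound 1 to compound 2 (0.81 log units; beyond the scatter). The unmeasured compound 4 `Cc1ccc(NC(=O)Nc2ccc(OC(=O)c3ccccc3)cc2)cc1` carries the same change, set on the core of compound 3 (methyl in place of fluoro on an aromatic carbon); among these compounds the change occurs twice in all, and the two places read alike. Because compound 3 stands at 94400 nM and the earlier step was a 6.4-fold lower number from compound 1 to compound 2 (0.81 log units; beyond the scatter), a step of similar size is expected here, a 5.2-fold lower number from compound 3 to compound 4 (0.72 log units; beyond the scatter), though it rests on a single measured pair and on a core that is not the same. Compound 4 is accordingly estimated at 18000 nM, with a likely range from 6000 nM to 55000 nM.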

Compound 4, half-maximal inhibitory concentration: 104000 nM
Beside the measured number, compound 4's estimate is 5.8-fold (0.76 log units) below it, outside the stated range (above it).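

In this assay, methyl in place of fluoro gave a 1.1-fold higher number from compound 3 to compound 4 (0.04 log units; within the scatter), so this pair offers no support for the larger step seen on the core of compound 1. Set side by side, the two results show that the step did not carry over from one core to the other in this series: the same change on two cores in this assay, a 6.4-fold lower number (0.81 log units; beyond the scatter) from compound 1 to compound 2 and a 1.1-fold higher number (0.04 log units; within the scatter) from compound 3 to compound 4, 7.1-fold (0.85 log units) apart, beyond the scatter of two such steps. This shows that a step measured on one of these cores cannot simply be transferred to the other, but with a single pair on each core it does not show what in the cores separates the two results, nor how the change would read on any further core.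

The compounds shown leave open how a chloro or a methoxy group would read in the place of the fluoro or the methyl on either core. They also leave open whether the two cores would still part if the ester link were replaced by an amide.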